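This account rests on a few compounds, and the source may have more. Where it says the series, first, only, none or still open, it means among the compounds named here.

Measured compounds:
- Compound 1, `O=C(CN1CCN(S(=O)(=O)c2cccnc2)CC1)Nc1ccccc1F`, gives 49600 nM in an in vitro assay on HEK ts201 cells for negative allosteric modulation of Neuronal acetylcholine receptor; alpha3/beta4 (Homo sapiens), read by fluorescence and calcium flux, with a stated time of 1.5 s; a higher number here means a weaker inhibitor, a lower number a stronger inhibitor.
- Compound 2, `O=C(CN1CCN(S(=O)(=O)c2ccccc2)CC1)Nc1ccccc1F`, gives 4000 nM in this assay.
- Compound 3, `COc1ccc(S(=O)(=O)N2CCN(CC(=O)Nc3ccccc3F)CC2)cc1`, gives 15400 nM in this assay.

Compound 1 has the highest number of the three, so it is the weakest inhibitor here: the step of a 12-fold lower number from compound 1 to compound 2 (1.09 log units; beyond the scatter) and the step of a 3.2-fold lower number from compound 1 to compound 3 (0.51 log units; beyond the scatter) both go to lower numbers, and between those two the step of a 3.9-fold higher number from compound 2 to compound 3 (0.59 log units; beyond the scatter) is modest. All three changes sit on the sulfonyl sulfur end of the shared core.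

Compound 4, `COc1ccc(NC(=O)CN2CCN(S(=O)(=O)c3cccnc3)CC2)cc1`, differs from compound 1 at the other end: 4-methoxyphenyl in place of 2-fluorophenyl on an amide-type nitrogen. Within the data shown here, no measured step touches this amide-type nitrogen, so none bears directly on the change. Among the measured compounds shown here, the only measured change involving a methoxy, the step of a 3.9-fold higher number from compound 2 to compound 3 (0.59 log units; beyond the scatter), is at a different place and gives no guide for the anilide side.

With nothing to anchor the step, compound 4 is expected to stay near compound 1, with the step of a 1.1-fold lower number from compound 1 to compound 4 (0.04 log units; within the scatter) treated as uncertain in either direction, and an estimate of 45000 nM with a range from 10000 nM to 150000 nM.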

Compound 4, half-maximal inhibitory concentration: 95000 nM
Compound 4: middle estimate off by 2.1-fold (0.32 log units), on the low side; low and high end bracket the measured number.
By their numbers in this assay, from the lowest: compound 2; then compound 3; then compounds 1 and 4 (each within the scatter of the next).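

Among these compounds, compound 4 gives the first reading at the amide-type nitrogen end of the shared core, as all the earlier steps lay on the sulfonyl sulfur. In this assay, putting 4-methoxyphenyl in place of 2-fluorophenyl gives a 1.9-fold higher number from compound 1 to compound 4 (0.28 log units; within the scatter), so this change cannot be told apart from no change at all, whereas each step on the sulfonyl sulfur lay beyond the scatter. Nothing at hand explains this result or shows how either group acts on the receptor.

This change swaps two groups at once, so the shown compounds cannot separate the fluorine from the methoxy, and a plain phenyl on the amide-type nitrogen would be needed to do so. As far as these compounds go, it also remains open whether a carboxylic acid or an amine on that ring would move the number, or whether the phenyl on the sulfonyl sulfur of compound 2 would alter the outcome.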